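From Methoxycarbonyl to 3-Methoxyphenyl on the Shared Core

A few compounds are considered here, and "the series" means these few. Any claim that something is new, unique, unknown or untested is made for them only; others in the source may bear on it.

Compound 1 `O=C(Nc1ccc2nc(NC(=O)C3CCCCC3)sc2c1)c1ccccc1F`: 0.14 ug/mL
Compound 2 `N#Cc1cccc(C(=O)Nc2ccc3nc(NC(=O)C4CCCCC4)sc3c2)c1`: 0.52 ug/mL
Compound 3 `COC(=O)Nc1nc2ccc(NC(=O)c3c(Cl)cccc3Cl)cc2s1`: 0.0095 ug/mL

In a functional assay on WI-38 VA13 cells (Homo sapiens) for cytotoxicity (a lower number here means that less compound is needed, a higher number that more compound is needed for the effect), compound 3 gives the lowest number of the three, with compound 1 and compound 2 both well above it. Compound 4 `COc1cccc(Nc2nc3ccc(NC(=O)c4c(Cl)cccc4Cl)cc3s2)c1` differs from compound 3 in one place: 3-methoxyphenyl in place of methoxycarbonyl on a nitrogen on an aromatic ring. Among the compounds with values here, the only measured step, a 3.7-fold higher number from compound 1 to compound 2 (0.57 log units; beyond the scatter), concerns the carbonyl side of the core and does not bear on a change at the ring nitrogen, so there is no measured anchor for this step. Compound 4 is therefore estimated with a wide range, as 0.03 ug/mL (0.005 ug/mL to 0.2 ug/mL), which means an expected step of a 3.2-fold higher number from compound 3 to compound 4 (0.50 log units; beyond the scatter).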

Compound 4, half-maximal effective concentration: > 7.2 ug/mL
Compound 4 was reported as a limit; the forecaster's own chance of this, stated with the estimate: 5%; middle value at least 240-fold (2.38 log units) away from the limit.
By their numbers in this assay, from the lowest: compound 3; then compound 1; then compound 2. At a limit, above all of these: compound 4.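

Replacing methoxycarbonyl with 3-methoxyphenyl on the nitrogen on an aromatic ring gives the first step seen at this position, and in this assay it is large: an at least 750-fold higher number from compound 3 to compound 4 (2.87 log units; beyond the scatter). The earlier step, a 3.7-fold higher number from compound 1 to compound 2 (0.57 log units; beyond the scatter), lay on the carbonyl side and gave no sign that this nitrogen's substituent could matter so strongly. The reading for compound 4 is a limit of the assay, not a number: the limit of > 7.2 ug/mL in this assay, at which 1 of the 4 values shown sits.

As far as these compounds go, it remains open whether an acetyl group or an unsubstituted phenyl on this nitrogen would stay near compound 3 or move toward compound 4.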